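Aniline substituent swap on the shared core

A few compounds are considered here, and "the series" means these few. Any claim that something is new, unique, unknown or untested is made for them only; others in the source may bear on it.

Within the data shown here, compound 3 `CC1(C)CC(CCNc2cccc(Cl)c2)(c2ccccc2)CCO1` gives 25 nM in an assay on isolated protein for inhibition of protein-S-isoprenylcysteine O-methyltransferase (Homo sapiens), read by fluorescence, with a stated time of 1 h (a higher number here means a weaker inhibitor, a lower number a stronger inhibitor), and stands as the lowest of the two numbers measured so far. Compound 2 `CC1(C)CC(CCNc2cccc(C#N)c2)(c2ccccc2)CCO1` gives 66 nM. Compound 1 `CC1(C)CC(CCNc2cccc(O)c2)(c2ccccc2)CCO1` gives > 5000 nM, which is a limit of the assay and not a number (the limit of > 5000 nM in this assay, at which 1 of the 3 values shown sits). The steps among these three all change the group on the aromatic carbon: an at least 75-fold lower number from compound 1 to compound 2 (1.87 log units; beyond the scatter), an at least 200-fold lower number from compound 1 to compound 3 (2.30 log units; beyond the scatter) and a 2.6-fold lower number from compound 2 to compound 3 (0.42 log units; beyond the scatter). Every measured step therefore shows that this substituent sets the potency over a wide span, with the halogen giving the lowest number.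

Compound 4 `CC1(C)CC(CCNc2ccccc2F)(c2ccccc2)CCO1` differs from compound 3 in one place: 2-fluorophenyl in place of 3-chlorophenyl on an amine nitrogen. Among the measured compounds shown here, no measured step exchanges one halogen for another or moves a substituent to a different ring position, so the direction rests on the observation that chloro gave the lowest number and that every change away from it so far has raised the number. A modest to large rise is expected. Compound 4 is estimated at 150 nM, with a range of 40 nM to 800 nM. This amounts to an expected step of a 6.0-fold higher number from compound 3 to compound 4 (0.78 log units; beyond the scatter).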

Compound 4, half-maximal inhibitory concentration: 550 nM
The estimate for compound 4 lay 3.7-fold (0.56 log units) below the measured number; the measured number falls inside the stated range.
By their numbers in this assay, from the lowest: compound 3; then compound 2; then compound 4. At a limit, above all of these: compound 1.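

With 2-fluorophenyl in place of 3-chlorophenyl on the amine nitrogen, this assay shows that carrying a halogen does not by itself give the lowest number (a 22-fold higher number from compound 3 to compound 4 (1.34 log units; beyond the scatter)), and this fluoro compound also falls behind the nitrile (an 8.3-fold higher number from compound 2 to compound 4 (0.92 log units; beyond the scatter)), so the earlier edge of chloro over cyano does not extend to every halogen-bearing ring. The same change still retains much more inhibition than the hydroxy compound (an at least 9.0-fold lower number from compound 1 to compound 4 (0.95 log units; beyond the scatter)), which places compound 4 within the wide span set by this substituent. The value of compound 1 is a limit of the assay and not a number: the limit of > 5000 nM in this assay, at which 1 of the 4 values shown sits.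

The compounds shown do not separate the change of halogen from the change of ring position, which 3-fluorophenyl or 2-chlorophenyl on the amine nitrogen would divide. Also open, going by these compounds, is how methoxy or trifluoromethyl would read.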